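Aryl swap on the amide-type nitrogen: outlook for compound 3

The compounds below may be only part of what the source reports. "The series", "measured", "known", "first", "only" and "open" are said of these compounds alone.

Measured in a functional assay on ACHN cells (Homo sapiens) for inhibition, read by sulforhodamine B assay, with a stated time of 48 h (on this read-out lower numbers stand for stronger inhibition of growth and higher numbers for weaker inhibition of growth), so far:
compound 1 `O=C(Nc1cccc(-n2cc(-c3ccncc3)c(-c3ccc(Cl)c(O)c3)n2)c1)Nc1cccc(C(F)(F)F)c1` — compound 1 gives 1290 nM
compound 2 `COc1cc(-c2nn(-c3cccc(NC(=O)Nc4ccc(Cl)c(Cl)c4)c3)cc2-c2ccncc2)ccc1Cl` — compound 2 gives 1000 nM

Compound 2 shows the lowest of the two numbers in this assay; its nearest neighbour is compound 1, and the two values lie within the scatter, so no order between them is claimed. Compound 3 `COc1cc(-c2nn(-c3cccc(NC(=O)Nc4cccc(C(F)(F)F)c4)c3)cc2-c2ccncc2)ccc1Cl` is the untested member. From compound 2 it differs by 3-(trifluoromethyl)phenyl in place of 3,4-dichlorophenyl on an amide-type nitrogen. Among the compounds with values here, no step between measured compounds covers this change. Compound 1 already carries the entering group on a different core partner and sits close to compound 2, so no shift beyond the scatter is expected; the estimated step of a 1.2-fold higher number from compound 2 to compound 3 (0.08 log units; within the scatter) is taken as flat. Compound 3 is expected at 1200 nM, within 500 nM to 3000 nM.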

Compound 3, concentration for 50% growth inhibition: 656 nM
For compound 3 the middle estimate is 1.8-fold (0.26 log units) above the measured one, and the stated range covers the measured number.
By their numbers in this assay, from the lowest: compounds 3, 2 and 1 (each within the scatter of the next).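

In this assay, 3-(trifluoromethyl)phenyl in place of 3,4-dichlorophenyl on the amide-type nitrogen gives a 1.5-fold lower number from compound 2 to compound 3 (0.18 log units; within the scatter) and so shows no readable shift for this change on the methoxy-bearing core. Methyl in place of hydrogen on the oxygen on the aromatic ring, a change not covered before, gives a 2.0-fold lower number from compound 1 to compound 3 (0.29 log units; within the scatter) and likewise shows no readable shift. No measurement available here accounts for either step.

Still open, going by these compounds, is whether a cyclohexyl group on this nitrogen would keep the values in this range. Also open, on these data alone, is how a longer chain such as ethyl on that oxygen would read.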